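Methyl homologation on a quaternary imidazolium oxime series

The source may report more compounds than this note shows. Statements on the series, on what has been measured and on what is new or still open speak of the compounds shown alone.

Compound 1 `CN(CCCn1cc[n+](C)c1/C=N/O)S(=O)(=O)C(F)(F)F` and compound 2 `CCN(CCCn1cc[n+](C)c1/C=N/O)S(=O)(=O)C(F)(F)F` share one core; compound 3 `CC[n+]1ccn(COCCS(C)(=O)=O)c1/C=N/O` and compound 4 `CCC[n+]1ccn(COCCS(C)(=O)=O)c1/C=N/O` share another, and the difference between the two cores is not broken down here. In a physicochemical assay for lipophilicity (on this read-out higher numbers stand for higher lipophilicity and lower numbers for lower lipophilicity), compound 1 gives -1.37, and compound 2 gives -1.02 in this assay. The change between them, (methyl in place of hydrogen on a saturated chain carbon bound to a sulfonamide nitrogen), produced a number 0.35 log units higher from compound 1 to compound 2 (beyond the scatter).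

Compound 3 sits at a limit of this assay rather than at a number: compound 3 gives < -3, a limit, as stated in the limit of < -3 in this assay, at which 1 of the 3 values shown sits.

Compound 4 differs from compound 3 by methyl in place of hydrogen on a saturated chain carbon, two bonds along the chain from an aromatic nitrogen. Going by the values given here, this is the same kind of change as the one from compound 1 to compound 2, but the place is not identical: in the first pair the methyl enters on a saturated chain carbon bound to a sulfonamide nitrogen, in the second on a saturated chain carbon, two bonds along the chain from an aromatic nitrogen.

Among the compounds with values here, on the strength of the one measured step, compound 1 to compound 2 with a number 0.35 log units higher from compound 1 to compound 2 (beyond the scatter), the step from compound 3 to compound 4 in this assay is expected to be of similar size, a step that the limit leaves unreadable from compound 3 to compound 4. Since compound 3 shows only a limit, the starting point is uncertain, and the estimated value for compound 4 in this assay is -3.1, between -3.8 and -2.5, with a fair chance that only a limit is returned again.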

Compound 4, distribution coefficient: < -3
Compound 4 gave a limit, no number; the forecaster's own chance of this, stated with the estimate: 60%; the middle value lies beyond the limit too.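

In this assay compound 4 gives < -3 as a limit and not a number. Going by these compounds alone, compound 3 also stands at a limit, so no step between compound 3 and compound 4 can be read. The compounds shown leave open whether the measured change (a number 0.35 log units higher from compound 1 to compound 2 (beyond the scatter)) carries over to methyl in place of hydrogen on a saturated chain carbon, two bonds along the chain from an aromatic nitrogen.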